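Swapping amino for hydroxymethyl on a shared core

The source may hold more compounds than are shown below. What is called first, only, known or untested is meant among the compounds shown, and "the series" means these compounds.

Of the compounds shown here, three sharing one core have been measured in a physicochemical assay for acid dissociation. Compound 1 `OCc1c(C(F)(F)F)nc2c(OCc3ccccc3)cccn12` gives 2, far from the other two. Compound 2 `Cc1nc2c(OCc3ccccc3)cccn2c1C` gives 7, and compound 3 `Cc1nc2c(OCc3ccccc3)cccn2c1N` gives 6.81. Compound 3 therefore sits level with compound 2 within the scatter, and well above compound 1.

Compound 4 `Cc1nc2c(OCc3ccccc3)cccn2c1CO` differs from compound 3 in one place: hydroxymethyl in place of amino on an aromatic carbon. This puts hydroxymethyl in place of amino on an aromatic carbon. Going by the values given here, the only measured single change on that carbon is small: a number 0.19 log units lower from compound 2 to compound 3 (within the scatter). Compound 1 also carries hydroxymethyl on that carbon, but it has trifluoromethyl as a second difference, so its 2 cannot be credited to hydroxymethyl alone. It does leave open a move downward, though nothing close to that size. The expected change is modest: a number 0.51 log units lower from compound 3 to compound 4 (beyond the scatter). For compound 4 the estimated value is 6.3, expected to fall between 5.6 and 6.9.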

Compound 4, acid dissociation constant: 6.1
Compound 4: middle estimate off by 0.20 log units, on the high side; measured number inside the range.
By their numbers in this assay, from the lowest: compound 1; then compound 4; then compounds 3 and 2 (each within the scatter of the next).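

In this assay, this aromatic carbon proves able to shift the number: hydroxymethyl in place of amino gives a number 0.71 log units lower from compound 3 to compound 4 (beyond the scatter), whereas the earlier change from methyl to amino stayed within the scatter. Hydroxy in place of hydrogen on the saturated chain carbon bound to that aromatic carbon gives a number 0.90 log units lower from compound 2 to compound 4 (beyond the scatter), so hydroxymethyl now has a single-change comparison against both methyl and amino. Methyl in place of trifluoromethyl on an aromatic carbon gives a number 4.10 log units higher from compound 1 to compound 4 (beyond the scatter), which ties the far lower number of compound 1 to trifluoromethyl rather than to hydroxymethyl.

As far as these compounds go, whether a carboxylic acid or a longer chain on the hydroxymethyl carbon would move the number further remains open. No evidence is available to explain the size of these steps.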